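The source may report more compounds than this note shows. Statements on the series, on what has been measured and on what is new or still open speak of the compounds shown alone.

Two compounds of the series carry numbers in a functional assay on SK-MEL-28 cells (Homo sapiens) for inhibition, read by sulforhodamine B assay, with a stated time of 48 h; on this read-out higher numbers stand for weaker inhibition of growth and lower numbers for stronger inhibition of growth. Compound 1 `Nc1cc(N)c2nc(-c3ccccc3)c(NCc3ccc(Cl)c(Cl)c3)nc2c1` gives 18600 nM in this assay. Compound 2 `Nc1cc(N)c2nc(-c3ccccc3)c(Sc3ccc(F)cc3)nc2c1` gives 23400 nM in this assay. Compound 1 holds the lower of the two numbers, but its gap to compound 2 lies within the scatter, so the pair stands level on this read-out and no order can be read from it.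

Compound 3 `COc1ccc(CNc2nc3cc(N)cc(N)c3nc2-c2ccccc2)cc1` has not been measured in this assay. It differs from compound 1 by 4-methoxyphenyl in place of 3,4-dichlorophenyl on a saturated chain carbon bound to a nitrogen on an aromatic ring. Among the measured compounds shown here, no step between measured compounds covers a change of this kind, and the two numbers in hand say nothing about it. The expectation is a step that stays near the scatter, if anything toward a higher number; the step is estimated at a 1.3-fold higher number from compound 1 to compound 3 (0.13 log units; within the scatter). Compound 3 is accordingly expected to give about 25000 nM in this assay, within a range from 8000 nM to 80000 nM.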

Compound 3, concentration for 50% growth inhibition: 17400 nM
For compound 3 the middle estimate is 1.4-fold (0.16 log units) above the measured one, and the stated range covers the measured number.
By their numbers in this assay, from the lowest: compounds 3, 1 and 2 (each within the scatter of the next).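

Replacing 3,4-dichlorophenyl with 4-methoxyphenyl on a saturated chain carbon bound to a nitrogen on an aromatic ring gives a 1.1-fold lower number from compound 1 to compound 3 (0.03 log units; within the scatter). Among the compounds shown here, this is the first step read at this position: both chlorine atoms leave and a hydrogen-bond acceptor enters, yet this assay does not separate compound 1 from compound 3. For this one pair, the read-out therefore tolerates the exchange of 3,4-dichlorobenzyl for 4-methoxybenzyl, and no wider claim on substituted benzyl groups follows from it. No measurement in hand bears on the reason for this result.

On these data alone, what a carboxylic acid on the phenyl ring would do in this assay stays open. So does the effect of a longer chain in place of the benzyl group.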